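Sulfonyl aryl variation in a three-compound series

This account rests on a few compounds, and the source may have more. Where it says the series, first, only, none or still open, it means among the compounds named here.

Measured compounds, all in an assay on MDA-MB-231 cells for binding affinity to C-X-C chemokine receptor type 4 (Homo sapiens), read by fluorescence and microscopy, with stated times of 10 min and 30 min; on this read-out higher numbers stand for an effect only at larger amounts of compound and lower numbers for an effect already at smaller amounts:
- compound 1 `O=C(NCc1ccc(CNS(=O)(=O)c2ccc3c(c2)CCO3)cc1)c1ccc(F)cc1`, compound 1 gives 10 nM
- compound 2 `O=C(NCc1ccc(CNS(=O)(=O)c2cccnc2)cc1)c1ccc(F)cc1`, compound 2 gives 1000 nM
- compound 3 `O=C(NCc1ccc(CNS(=O)(=O)c2ccccc2Cl)cc1)c1ccc(F)cc1`, compound 3 gives 1000 nM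

Compound 3 sits level with compound 2 at the digits shown, the two together the highest numbers of the three; its only clear separation is from compound 1, seen as a 100-fold higher number from compound 1 to compound 3 (2.00 log units; beyond the scatter). The parallel step a 100-fold higher number from compound 1 to compound 2 (2.00 log units; beyond the scatter) is of the same size, so the bicyclic group on the sulfonyl sulfur in compound 1 is the one feature that sets it apart, while the swap no change at the digits printed from compound 2 to compound 3 (within the scatter) between two monocyclic groups left the number untouched.

The next compound, compound 4 `O=C(NCc1ccc(CNS(=O)(=O)c2cccc(C(F)(F)F)c2)cc1)c1ccc(F)cc1`, differs from compound 3 by 3-(trifluoromethyl)phenyl in place of 2-chlorophenyl on a sulfonyl sulfur.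

The step that bears on this change is no change at the digits printed from compound 2 to compound 3 (within the scatter): one monocyclic aryl on the sulfonyl sulfur for another gave nothing beyond the scatter. The large steps of a 100-fold higher number from compound 1 to compound 2 (2.00 log units; beyond the scatter) and a 100-fold higher number from compound 1 to compound 3 (2.00 log units; beyond the scatter) concern loss of the bicyclic group, which is not at issue here. In this assay a step of no change at the digits printed from compound 3 to compound 4 (within the scatter) is therefore expected, that is, none beyond the scatter. Compound 4 is estimated at 1000 nM, within 300 nM to 3000 nM.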

Compound 4, effective concentration (reported as EC, without a stated level of effect): 100 nM
Beside the measured number, compound 4's estimate is 10-fold (1.00 log units) above it; the whole stated range lies above it.
By their numbers in this assay, from the lowest: compound 1; then compound 4; then compounds 2 and 3 (each within the scatter of the next).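

In this assay, the monocyclic groups on the sulfonyl sulfur no longer behave as interchangeable: 3-(trifluoromethyl)phenyl separates from both 2-chlorophenyl (a 10-fold lower number from compound 3 to compound 4 (1.00 log units; beyond the scatter)) and pyridin-3-yl (a 10-fold lower number from compound 2 to compound 4 (1.00 log units; beyond the scatter)), so this position responds to the choice of monocyclic aryl and not only to the loss of the bicyclic group. Compound 1 still holds the lowest number (a 10-fold higher number from compound 1 to compound 4 (1.00 log units; beyond the scatter)), which places compound 4 part-way along the range and shows that a group without a second ring can recover part of the gap between the bicyclic group and the other two monocyclic groups, though not all of it. Nothing available accounts for this separation, and the basis for the gain of 3-(trifluoromethyl)phenyl over the other two groups remains unexplained.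

The compounds shown leave open whether the step from 2-chlorophenyl follows from the exchange of chlorine for trifluoromethyl or from the different place of the substituent on the phenyl ring. They also leave open whether a nitrile, a methoxy group or an amine on that ring would read with compound 4 or with compound 3.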